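The compounds below may be only part of what the source reports. "The series", "measured", "known", "first", "only" and "open" are said of these compounds alone.

The study covers a small set of compounds that share one core and were examined in a physicochemical assay for lipophilicity; on this read-out lower numbers stand for lower lipophilicity and higher numbers for higher lipophilicity. Compound 1 `Nc1ccc(CNc2nc3ccccc3c(=O)o2)cc1` gives 2 in this assay. Compound 3 `O=c1oc(N2CCCCC2)nc2ccccc12` gives 3 in this assay. Compound 2 `COC(=O)[C@H](CC(C)C)Nc1nc2cccc(C)c2c(=O)o1` gives 3.7 in this assay, the highest of the three numbers: its nearest neighbour is compound 3, which lies lower by more than the usual scatter, and compound 1 lies further below it, also beyond the scatter. No two of these measured compounds differ in only one place, so no single step can be read off from them.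

Compound 4 `COC(=O)[C@H](CC(C)C)Nc1nc2cc(C)cc(C)c2c(=O)o1` has not yet been measured. It differs from compound 2 by methyl in place of hydrogen on an aromatic carbon. Within the data shown here, with no measured step of this kind to lean on, the expectation rests on compound 2, which already stands at 3.7, and on the size of the change, which is a single carbon. A modest rise in this assay, somewhat beyond the scatter rather than no change or a fall, is what is expected. Compound 4 is therefore estimated to give 4.2, with a range from 3.8 to 4.6. The step of a number 0.50 log units higher from compound 2 to compound 4 (beyond the scatter) implied by this estimate is expected to be small but clear.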

Compound 4, distribution coefficient: 4
Compound 4: middle estimate off by 0.20 log units, on the high side; the measured number falls inside the stated range.
By their numbers in this assay, from the lowest: compound 1; then compound 3; then compounds 2 and 4 (each within the scatter of the next).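

Among these compounds, this is the first step in the set that can be read in one place: methyl in place of hydrogen on an aromatic carbon, meta to a methyl group and para to a fused ring, gives a number 0.30 log units higher from compound 2 to compound 4 (within the scatter) in this assay. At this position, then, a change of one carbon does not carry the number past what repeated measurements would scatter over, so the two compounds cannot be told apart on this read-out. The earlier compounds differ from one another in more than one place and could show only a spread of numbers, not what a single methyl does here, and nothing measured alongside this result offers a reason for it.

What the compounds shown leave open is whether a different group on this same aromatic carbon, such as a methoxy group, a chlorine atom or a longer chain, would give a step beyond the scatter. They also leave open whether methyl at this position would read the same with a carboxylic acid in place of the methyl ester on the side chain.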